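The compounds below may be only part of what the source reports. "The series", "measured", "known", "first", "only" and "open" are said of these compounds alone.

Going by the values given here, in a functional assay on DLD-1 cells (Homo sapiens) for antiproliferative activity, read by CellTiter-Glo, with a stated time of 72 h (on this read-out higher numbers stand for weaker inhibition and lower numbers for stronger inhibition), two compounds have numbers so far. Compound 1 (`CC1CCN(C2CCN(S(=O)(=O)c3ccccc3Br)CC2)CC1`) gives 3 nM, and compound 2 (`Cc1ccc(S(=O)(=O)N2CCC(N3CCC(C)CC3)CC2)cc1C`) gives 24 nM, the higher of the two numbers. Among the compounds with values here, the single measured step, an 8.0-fold higher number from compound 1 to compound 2 (0.90 log units; beyond the scatter), came with 3,4-dimethylphenyl in place of 2-bromophenyl on a sulfonyl sulfur.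

Compound 3 (`CC1CCN(C2CCN(S(=O)(=O)c3ccc(Br)c(Cl)c3)CC2)CC1`) awaits measurement. Relative to compound 2, it carries 4-bromo-3-chlorophenyl in place of 3,4-dimethylphenyl on a sulfonyl sulfur. Within the data shown here, the step to compound 2 is the only measured one at this place, so it is the only guide. Compound 1, which has a bromine-bearing group here, sits at 3 nM, so some return toward that number is expected. However, 4-bromo-3-chlorophenyl is a different group from 2-bromophenyl, and two compounds establish no trend, so only part of that step is expected to be recovered. The estimated change is a 2.4-fold lower number from compound 2 to compound 3 (0.38 log units; beyond the scatter), which would be smaller than the measured step and toward stronger inhibition. For compound 3 the estimate is 10 nM, with an expected range from 3 nM to 35 nM.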

Compound 3, half-maximal inhibitory concentration: 12 nM
Compound 3: middle estimate off by 1.2-fold (0.08 log units), on the low side, and the stated range covers the measured number.
By their numbers in this assay, from the lowest: compound 1; then compounds 3 and 2 (each within the scatter of the next).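

In this assay, 4-bromo-3-chlorophenyl in place of 3,4-dimethylphenyl on the sulfonyl sulfur gives a 2.0-fold lower number from compound 2 to compound 3 (0.30 log units; within the scatter), so these two groups, each with 8 heavy atoms, cannot be told apart at this position. Going by these compounds alone, a bromine on the aromatic ring is not enough to reach the number of compound 1: 4-bromo-3-chlorophenyl in place of 2-bromophenyl gives a 4.0-fold higher number from compound 1 to compound 3 (0.60 log units; beyond the scatter), and compound 3 therefore goes against any simple link between bromine and a low number, leaving 2-bromophenyl as the one group of the three that stands apart beyond the scatter. No supporting data bear on what lies behind this difference.

Going by these compounds, how an unsubstituted phenyl, a pyridine ring, or a phenyl ring bearing an amine or a carboxylic acid would read on this sulfonyl sulfur remains open. On these data alone, the rest of the core is the same in all three compounds, so the effect of any change elsewhere, such as replacing the methyl group with a longer chain, also stays unknown.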